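The compounds below may be only part of what the source reports. "The series", "measured", "known", "first", "only" and "open" are said of these compounds alone.

In an ADME assay on Raji cells (Homo sapiens) for cytotoxicity, with a stated time of 72 h (on this read-out higher numbers stand for an effect only at larger amounts of compound and lower numbers for an effect already at smaller amounts), compound 1 (`CC(=O)c1ccc(NC(=O)Nc2cc(C)nc3ccccc23)cc1`) gives > 25000 nM, which is a limit of the assay. Compound 3 (`Cc1cc(NC(=O)Nc2cc(Cl)cc(Cl)c2)c2ccccc2n1`) gives > 25000 nM, also a limit. Compound 2 (`Cc1cc(NC(=O)Nc2ccccc2C(C)(C)C)c2ccccc2n1`) gives > 25000 nM, again only a limit, so no number places it among the others. Across these compounds the picture is the limit of > 25000 nM in this assay, at which 3 of the 3 values shown sit. Compound 4 (`Cc1cc(NC(=O)Nc2ccccc2C(N)=O)c2ccccc2n1`) has carbamoyl in place of tert-butyl on an aromatic carbon, ortho to a large group: carbamoyl in place of tert-butyl on an aromatic carbon. Among the measured compounds shown here, no measured pair shows the effect of such a change. The expectation starts from compound 2, which gives the limit > 25000 nM. The step of a number no higher from compound 2 to compound 4 (the limit leaves the size open) is expected to stay within the scatter, in neither direction. Compound 4 is estimated at 25000 nM, with an expected range of 12000 nM to 50000 nM.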

Compound 4, half-maximal effective concentration: > 25000 nM
Compound 4 ended at the assay's limit; the forecaster's own chance of this, stated with the estimate: 85%; the middle value lies on the limit itself.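

Compound 2 and compound 4 each give only a limit, so no step can be read between them. The compounds shown leave open how any of them would rank if a number were available: the limit of > 25000 nM in this assay, at which 4 of the 4 values shown sit.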